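A Hydroxyphenyl in Place of Difluorophenyl on the Triazole

This account rests on a few compounds, and the source may have more. Where it says the series, first, only, none or still open, it means among the compounds named here.

The measured compounds and their values in a functional assay on HCT-116 cells (Homo sapiens) for antiproliferative activity, read by MTT assay, with a stated time of 72 h; a lower number here means a stronger inhibitor, a higher number a weaker inhibitor:
compound 1, `O=C1O/C(=C\Cn2cc(-c3cc(F)cc(F)c3)nn2)C(OCc2ccccc2)=C1OCc1ccccc1`, > 100000 nM
compound 2, `O=C1O[C@H]([C@@H](O)Cn2cc(C3CC3)nn2)C(OCc2ccccc2)=C1OCc1ccccc1`, 30400 nM
compound 3, `O=C1O[C@H]([C@@H](O)Cn2cc(CCCCl)nn2)C(OCc2ccccc2)=C1OCc1ccccc1`, 36100 nM

Compound 1 gives no number in this assay but only a limit, (the limit of > 100000 nM in this assay, at which 1 of the 3 values shown sits). Within the data shown here, compounds 2 and 3, which carry a hydroxyl-bearing saturated linker in place of the exocyclic double bond of compound 1, lie near each other, and the step of a 1.2-fold higher number from compound 2 to compound 3 (0.07 log units; within the scatter) is the only single-point comparison available.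

Compound 4, `O=C1O/C(=C\Cn2cc(-c3cccc(O)c3)nn2)C(OCc2ccccc2)=C1OCc1ccccc1`, arises from compound 1 by 3-hydroxyphenyl in place of 3,5-difluorophenyl on an aromatic carbon. Among the measured compounds shown here, no measured step touches the aryl group on the triazole, and compounds 2 and 3 differ from compound 1 at more than one place, so none of them bears directly on this change. For the measured compounds named here, the only evidence about compound 1 is its limit, and a compound this weak leaves much room on the weaker side and little firm ground on the stronger side.

Compound 4 is therefore expected to stay weak, with an estimated step of an at least 1.2-fold lower number from compound 1 to compound 4 (0.09 log units; that floor lies within the scatter) that is uncertain in both directions. The estimate for compound 4 in this assay is 80000 nM, with a range from 20000 nM to 300000 nM, and a substantial chance that only a limit is reported again.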

Compound 4, half-maximal inhibitory concentration: 63600 nM
Beside the measured number, compound 4's estimate is 1.3-fold (0.10 log units) above it; measured number inside the range.
By their numbers in this assay, from the lowest: compounds 2, 3 and 4 (each within the scatter of the next, the first and the last beyond it). At a limit, above all of these: compound 1.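

In this assay, the aryl group on the five-membered aromatic ring with 3 nitrogen now has its first measured step, with 3-hydroxyphenyl in place of 3,5-difluorophenyl giving an at least 1.5-fold lower number from compound 1 to compound 4 (0.19 log units; that floor lies within the scatter). With this change, compound 4 gives a number, 63600 nM, so this aryl position can carry a value inside the range of the assay on the exocyclic double bond linker. The true size of the step stays unknown, and only its floor can be read, since compound 1 gives a limit and not a number: the limit of > 100000 nM in this assay, at which 1 of the 4 values shown sits.

The compounds shown leave open whether an amine, a methoxy group or a carboxylic acid on the phenyl ring would give a lower number than the 3-hydroxyphenyl of compound 4. They also leave open how 3-hydroxyphenyl behaves on the hydroxyl-bearing saturated linker of compound 2 and compound 3.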